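Chloro for Fluoro: Expected Dose in Whole-Animal Testing

The source may hold more compounds than are shown below. What is called first, only, known or untested is meant among the compounds shown, and "the series" means these compounds.

Measured compounds:
compound 1, `COc1ccc(-c2cc(-c3ccc(F)cc3)nc(NC(=O)N/N=C\c3cccc(Cl)c3)n2)cc1OC` — 300 mg/kg
compound 2, `C/C(=N/NC(=O)Nc1nc(-c2ccc(C)cc2)cc(-c2ccc(F)cc2)n1)c1ccc([N+](=O)[O-])cc1` — 300 mg/kg
compound 3, `COc1ccc(-c2cc(-c3ccc(Cl)cc3)nc(NC(=O)N/N=C\c3cccc(Cl)c3)n2)cc1OC` — 300 mg/kg

In a functional assay on the whole organism (strain Albino) with Mus musculus as the target, with a stated time of 4 h (on this read-out lower numbers stand for an effect already at smaller amounts and higher numbers for an effect only at larger amounts of compound), compound 1 gives 300 mg/kg and compound 3 gives 300 mg/kg. The two differ by chloro in place of fluoro on an aromatic carbon, and that step reads no change at the digits printed from compound 1 to compound 3 (within the scatter). Compound 2 gives 300 mg/kg in this assay and sits level with compounds 1 and 3; the difference between the core of compound 2 and the core of compound 1 is not broken down here.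

Compound 4, `C/C(=N/NC(=O)Nc1nc(-c2ccc(C)cc2)cc(-c2ccc(Cl)cc2)n1)c1ccc([N+](=O)[O-])cc1`, is not yet measured. It differs from compound 2 by chloro in place of fluoro on an aromatic carbon, the same change that carried compound 1 to compound 3, at the same kind of place. Because no change at the digits printed from compound 1 to compound 3 (within the scatter) showed no movement, the step from compound 2 to compound 4 is expected to read no change at the digits printed from compound 2 to compound 4 (within the scatter). Compound 4 is therefore estimated at 300 mg/kg, within 150 mg/kg to 600 mg/kg.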

Compound 4, dose for half-maximal effect: 300 mg/kg
For compound 4 middle estimate and measured number coincide at the digits printed, and the stated range covers the measured number.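

Chloro in place of fluoro on the core of compound 2 gives no change at the digits printed from compound 2 to compound 4 (within the scatter) in this assay. Set beside the earlier case, the same exchange reads alike on the two cores: the same change on two cores in this assay, no change at the digits printed (within the scatter) from compound 1 to compound 3 and no change at the digits printed (within the scatter) from compound 2 to compound 4, 1.0-fold (0.00 log units) apart, within the scatter of two such steps This shows that the exchange carried from one core to the other in this assay, but it rests on two pairs alone and does not show that a third core would behave the same way, nor does it explain the shared reading.

The compounds shown leave open how an amine or a carboxylic acid on that aromatic carbon would read against fluoro and chloro. They also leave open whether any other group would shift the dose in this series.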